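Swapping the aryl group on a weakly active thiazolidine amide

The compounds below may be only part of what the source reports. "The series", "measured", "known", "first", "only" and "open" are said of these compounds alone.

Two compounds of this small set share a core built around a five-membered ring carrying a long chain amide. Compound 1 `CCCCCCCCCCCCCCCCCCNC(=O)[C@H]1CSC(c2cccc(O)c2)N1` bears a 3-hydroxyphenyl group on a saturated ring carbon, and in a functional assay on RH7777 cells (Homo sapiens) for antiproliferative activity against RH7777 (Rattus norvegicus), read by sulforhodamine B assay (on this read-out higher numbers stand for weaker inhibition and lower numbers for stronger inhibition), compound 1 gives 31000 nM. Compound 2 `CCCCCCCCCCCCCCCCCCNC(=O)[C@H]1CSC(c2cc(F)cc(F)c2)N1` carries a 3,5-difluorophenyl group in the same place. For compound 2 the assay returns only a limit, > 20000 nM, so compound 2 stands at the edge of what this assay can read, as the limit of > 20000 nM in this assay, at which 1 of the 2 values shown sits, records. The step that the limit leaves unreadable from compound 1 to compound 2 therefore has no readable size.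

Compound 3 `CCCCCCCCCCCCCCCCCCNC(=O)[C@H]1CSC(c2ccc(C)cc2)N1` differs from compound 2 by the change (4-methylphenyl in place of 3,5-difluorophenyl on a saturated ring carbon). Among the measured compounds shown here, the only measured step bearing on it is unreadable, so no direction beyond the scatter can be inferred. Compound 3 is expected to remain in the weak range, at an estimated 30000 nM (range 10000 nM to 100000 nM), an expected step that the limit leaves unreadable from compound 2 to compound 3.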

Compound 3, half-maximal inhibitory concentration: > 20000 nM
Compound 3 ended at the assay's limit; the forecaster's own chance of this, stated with the estimate: 55%; the middle value does not contradict the limit.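

The steps linking compound 3 to compound 1 and compound 2 cannot be read, since compound 3, like compound 2, gives only a limit: the limit of > 20000 nM in this assay, at which 2 of the 3 values shown sit.

Still open, going by these compounds, is how far compound 1, compound 2 and compound 3 truly differ in strength.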